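Vero cytotoxicity across ring substituents of the shared core

A few compounds are considered here, and "the series" means these few. Any claim that something is new, unique, unknown or untested is made for them only; others in the source may bear on it.

Measured so far in an ADME assay on Vero cells (Chlorocebus sabaeus) for cytotoxicity, with a stated time of 7 days; a lower number here means that less compound is tolerated, a higher number that more compound is tolerated:
- compound 1, `COc1cccc(CN2C(=O)CN(C(=O)c3cc4cc(OC)ccc4[nH]3)C[C@@H]2COCc2ccccc2)c1`, gives > 10000 nM, a limit of the assay.
- compound 2, `COc1cccc(CN2C(=O)CN(C(=O)c3cc4cc(OC)ccc4[nH]3)C[C@@H]2CCc2ccccc2)c1`, gives 4500 nM.
- compound 3, `COc1cccc(CN2C(=O)CN(C(=O)c3cc4cc(OC)ccc4[nH]3)C[C@@H]2c2ccccc2)c1`, gives > 10000 nM, a limit of the assay.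

Compound 3 thus stands only at a limit in this assay, at the limit of > 10000 nM in this assay, at which 2 of the 3 values shown sit. Among the measured compounds shown here, the steps into it read a step that the two limits leave unreadable from compound 1 to compound 3 and an at least 2.2-fold higher number from compound 2 to compound 3 (0.34 log units; beyond the scatter); the step of an at least 2.2-fold lower number from compound 1 to compound 2 (0.34 log units; beyond the scatter) is the only one between two numbers.

The next compound, compound 4, `COc1cccc(CN2C(=O)CN(C(=O)c3cc4cc(OC)ccc4[nH]3)C[C@@H]2CC2CCCCC2)c1`, carries cyclohexylmethyl in place of phenyl on a saturated ring carbon. For the measured compounds named here, no measured pair exchanges an aromatic ring for a saturated one, so the measured steps bear on it only loosely: compound 2, with a phenethyl group, sits at a number, while compound 3 and compound 1 sit at the limit. The saturated group is expected to land between those cases.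

The expected step is an at least 1.4-fold lower number from compound 3 to compound 4 (0.15 log units; that floor lies within the scatter) in this assay. Compound 4 is estimated at 7000 nM, with a range from 3000 nM to 20000 nM.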

Compound 4, half-maximal cytotoxic concentration: > 10000 nM
Compound 4 gave a limit, no number; the forecaster's own chance of this, stated with the estimate: 45%; middle value at least 1.4-fold (0.15 log units) away from the limit.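

In this assay compound 4 gives > 10000 nM, a limit of the assay, so a non-aromatic ring on this saturated ring carbon reads no differently from the phenyl of compound 3. The exchange of benzyl for cyclohexyl on the chain gives an at least 2.2-fold higher number from compound 2 to compound 4 (0.34 log units; beyond the scatter), which shows that the number of compound 2 does not hold for every carbon-only ring group at this position. The steps from compound 1 and compound 3 to compound 4 join two limits and cannot be read, and the series gathers at one value: the limit of > 10000 nM in this assay, at which 3 of the 4 values shown sit.

As far as these compounds go, that step shortens the link and removes the aromatic ring together, so the share of each stays open. A cyclohexylethyl group would separate the two, and an amine on the chain would test a group outside these carbon and ether cases.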